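This account rests on a few compounds, and the source may have more. Where it says the series, first, only, none or still open, it means among the compounds named here.

Measured so far:
compound 1 `O=C(Nc1ccc(C(=O)N2CCCN(CCN3CCCC3)c3sccc32)cc1)c1ccccc1-c1ccccc1` gives 200 nM in an assay on CHO cells for inhibition of Vasopressin V2 receptor (Homo sapiens), read by radioligand binding; on this read-out lower numbers stand for stronger inhibition and higher numbers for weaker inhibition
compound 2 `CN1CCCN(C(=O)CCCOc2cc(C(=O)N3CCCCc4sccc43)ccc2NC(=O)c2ccccc2-c2ccccc2)CC1` gives 10 nM in this assay

Of these two, compound 2 has the lower number, and its distance from compound 1 lies beyond the usual scatter. Compound 3 `CCN(CC)C1CCN(C(=O)CCCOc2cc(C(=O)N3CCCCc4sccc43)ccc2NC(=O)c2ccccc2-c2ccccc2)CC1` has not been measured. It differs from compound 2 in one place: 4-(diethylamino)piperidin-1-yl in place of 4-methyl-1,4-diazepan-1-yl on a carbonyl carbon. Among the compounds with values here, no step between two measured compounds matches this change, so nothing in the data points firmly up or down. The step from compound 2 to compound 3 is expected to be no change at the digits printed from compound 2 to compound 3 (within the scatter), that is, no change beyond the scatter. Compound 3 is therefore estimated at 10 nM, with a range from 3 nM to 30 nM.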

Compound 3, half-maximal inhibitory concentration: 9 nM
Estimate against measurement, compound 3: 1.1-fold (0.05 log units) above, and the stated range covers the measured number.
By their numbers in this assay, from the lowest: compounds 3 and 2 (each within the scatter of the next); then compound 1.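

In this assay the change to 4-(diethylamino)piperidin-1-yl on a carbonyl carbon gives a 1.1-fold lower number from compound 2 to compound 3 (0.05 log units; within the scatter) and so leaves the read-out within the scatter. Within the data shown here, this position therefore tolerates a swap from a seven-membered ring with 8 heavy atoms to a six-membered ring with 11 heavy atoms, something the earlier compounds could not show. No supporting data bear on this result. Still open, on these data alone, is whether a group without a second nitrogen, such as a carboxylic acid or a phenyl ring, would keep the number in the same range.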